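A few compounds are considered here, and "the series" means these few. Any claim that something is new, unique, unknown or untested is made for them only; others in the source may bear on it.

Compound 1, `CCN(CC)S(=O)(=O)c1ccc(S(=O)(=O)N2CCC[C@@H](C(=O)N3CCC(O)CC3)C2)cc1`, gives 4710 nM in a functional assay on BXPC-3 cells (Homo sapiens) for inhibition, read by MTT assay, with a stated time of 7 days; on this read-out lower numbers stand for stronger inhibition and higher numbers for weaker inhibition. Compound 2, `CCN(CC)S(=O)(=O)c1ccc(S(=O)(=O)N2CCC[C@@H](C(=O)NC3COC3)C2)cc1`, gives 13800 nM. Compound 3, `CCN(CC)S(=O)(=O)c1ccc(S(=O)(=O)N2CCC[C@@H](C(=O)N3CCC(C(F)(F)F)CC3)C2)cc1`, gives 370 nM.

Compound 3 stands lowest of the three, and both gaps lie beyond the scatter: a 13-fold lower number from compound 1 to compound 3 (1.10 log units; beyond the scatter) and a 37-fold lower number from compound 2 to compound 3 (1.57 log units; beyond the scatter). Compound 4, `CCN(CC)S(=O)(=O)c1ccc(S(=O)(=O)N2CCC[C@@H](C(=O)N3CC[C@@H](OC)C3)C2)cc1`, differs from compound 3 in one place: 3-methoxypyrrolidin-1-yl in place of 4-(trifluoromethyl)piperidin-1-yl on a carbonyl carbon. The step from compound 1 to compound 3 bears most on this change, as it also concerns the trifluoromethyl against an oxygen-bearing group; the step from compound 2 to compound 3 also saw the trifluoromethyl enter. Both steps were large, so a clear rise in this assay is expected for compound 4, though not beyond the number of compound 1. Compound 4 is therefore estimated at 2500 nM, within 800 nM to 8000 nM. This amounts to an expected step of a 6.8-fold higher number from compound 3 to compound 4 (0.83 log units; beyond the scatter).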

Compound 4, half-maximal inhibitory concentration: 11500 nM
The estimate for compound 4 lay 4.6-fold (0.66 log units) below the measured number; measured number above the stated range.
By their numbers in this assay, from the lowest: compound 3; then compound 1; then compounds 4 and 2 (each within the scatter of the next).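

In this assay, replacing 4-(trifluoromethyl)piperidin-1-yl with 3-methoxypyrrolidin-1-yl on the carbonyl carbon gives a 31-fold higher number from compound 3 to compound 4 (1.49 log units; beyond the scatter), a step as large as that seen with the (oxetan-3-yl)amino group. Against that group the new ring stays within the scatter, with a 1.2-fold lower number from compound 2 to compound 4 (0.08 log units; within the scatter), while against 4-hydroxypiperidin-1-yl it gives a 2.4-fold higher number from compound 1 to compound 4 (0.39 log units; beyond the scatter), so among these four compounds only the trifluoromethyl compound stands far apart. The data offer no measured basis for explaining these steps. Still open, as far as these compounds go, is whether 4-methoxypiperidin-1-yl or 3-(trifluoromethyl)pyrrolidin-1-yl would separate the effect of ring size from that of the ring substituent.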